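Trifluoromethyl for Methyl in a Cytotoxicity Series

A few compounds are considered here, and "the series" means these few. Any claim that something is new, unique, unknown or untested is made for them only; others in the source may bear on it.

The shared core appears in compound 1 `CCC1(Cc2ccccc2)OS(=O)(=O)C=C1OCc1ccc(OC)cc1`, compound 2 `CCC1(Cc2ccccc2)OS(=O)(=O)C=C1OCc1ccc(C)cc1` and compound 3 `CCC1(Cc2ccccc2)OS(=O)(=O)C=C1OC(=O)c1ccccc1`. In an ADME assay on HEL cells (Homo sapiens) for cytotoxicity, with a stated time of 3 days (on this read-out higher numbers stand for lower toxicity in this test and lower numbers for higher toxicity in this test), compound 1 reaches only an assay limit, >= 200000 nM. In this assay compound 2 likewise stops at a limit, >= 16000 nM. In this assay compound 3 gives the limit > 400000 nM. Because all three values are limits, compound 2 cannot be placed against the other two, and the steps a step that the two limits leave unreadable from compound 1 to compound 2 and a step that the two limits leave unreadable from compound 2 to compound 3 have no readable size. Compound 4 `CCC1(Cc2ccccc2)OS(=O)(=O)C=C1OCc1ccc(C(F)(F)F)cc1` carries trifluoromethyl in place of methyl on an aromatic carbon. Within the data shown here, no measured step of readable size bears on this change, so no step beyond the scatter is expected. Compound 4 is therefore estimated at 40000 nM, from 8000 nM to 400000 nM, in this assay. The expected step is a step that the limit leaves unreadable from compound 2 to compound 4.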

Compound 4, minimum cytotoxic concentration: >= 16000 nM
Compound 4: no number, only a limit; the forecaster's own chance of this, stated with the estimate: 75%; the middle value lies beyond the limit too.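

In this assay compound 4 gives only a limit, and its steps from compound 2 and from compound 1 cannot be read. The compounds shown leave open whether trifluoromethyl in place of methyl changes the minimum cytotoxic concentration at all.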